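The source may report more compounds than this note shows. Statements on the series, on what has been measured and on what is new or still open speak of the compounds shown alone.

Measured compounds: compound 1 `N#Cc1c(N)nc(SCC(N)=O)c(C#N)c1-c1ccc(OCC2CC2)cc1`, 31 nM; compound 2 `N#Cc1c(N)nc(SCc2ccn[nH]2)c(C#N)c1-c1ccc(OCC2CC2)cc1`, 84 nM; compound 3 `N#Cc1c(N)nc(SCc2cccc(C(N)=O)c2)c(C#N)c1-c1ccc(OCC2CC2)cc1`, 12.7 nM.

In a functional assay on CHO cells for agonist activity at adenosine receptor A2b (Homo sapiens), read by AlphaScreen and cAMP accumulation (a higher number here means that more compound is needed for the effect, a lower number that less compound is needed), compound 3 stands lowest of the three, the nearest being compound 1 by a 2.4-fold lower number from compound 1 to compound 3 (0.39 log units; beyond the scatter) in reverse, the furthest compound 2 by a 6.6-fold lower number from compound 2 to compound 3 (0.82 log units; beyond the scatter) in reverse. Compound 4 `CNC(=O)CSc1nc(N)c(C#N)c(-c2ccc(OCC3CC3)cc2)c1C#N` differs from compound 3 by methylcarbamoyl in place of 3-carbamoylphenyl on a saturated chain carbon bound to a sulfur. The bearing step is a 2.4-fold lower number from compound 1 to compound 3 (0.39 log units; beyond the scatter), which shows that removing the aromatic ring at this position and leaving only an amide costs potency modestly; a 6.6-fold lower number from compound 2 to compound 3 (0.82 log units; beyond the scatter) points the same way for a different ring. A modest rise in this assay is therefore expected for compound 4, about a 2.4-fold higher number from compound 3 to compound 4 (0.37 log units; beyond the scatter), with the amide retained. Compound 4 is estimated at 30 nM, range 12 nM to 75 nM.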

Compound 4, half-maximal effective concentration: 94 nM
For compound 4 the middle estimate is 3.1-fold (0.50 log units) below the measured one, and the stated range ends below it.
By their numbers in this assay, from the lowest: compound 3; then compound 1; then compounds 2 and 4 (each within the scatter of the next).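

In this assay, methyl in place of hydrogen on an amide-type nitrogen is not silent at this position, with a 3.0-fold higher number from compound 1 to compound 4 (0.48 log units; beyond the scatter) beyond the scatter. The change to methylcarbamoyl gives a 7.4-fold higher number from compound 3 to compound 4 (0.87 log units; beyond the scatter), while a 1.1-fold higher number from compound 2 to compound 4 (0.05 log units; within the scatter) is within the scatter, so methylcarbamoyl and 1H-pyrazol-5-yl on this carbon cannot be told apart here. No evidence at hand explains these steps. Open, as far as these compounds go, is whether ethyl on the amide nitrogen differs from methyl. Also open, from the compounds shown here alone, is whether a carboxylic acid or an amine in place of the carbamoyl of 3-carbamoylbenzyl keeps the value of compound 3.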